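The source may hold more compounds than are shown below. What is called first, only, known or untested is meant among the compounds shown, and "the series" means these compounds.

Compound 1 `CCCCNC(=O)Nc1cc(/C(=N/O)Nc2ccc(F)c(Br)c2)ccc1N(CC(C)C)CC(C)C` gives 3110 nM in an assay on HeLa cells for inhibition of Indoleamine 2,3-dioxygenase 1 (Homo sapiens); on this read-out higher numbers stand for weaker inhibition and lower numbers for stronger inhibition. Compound 2 `CCCNC(=O)Nc1cc(/C(=N/O)Nc2ccc(F)c(Br)c2)ccc1N(CC(C)C)CC(C)C` gives 2610 nM in this assay.

On the numbers shown, compound 2 sits at the low end of the two, but the only measured step, a 1.2-fold lower number from compound 1 to compound 2 (0.08 log units; within the scatter), falls within the scatter, so compound 1 and compound 2 cannot be told apart on this read-out.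

Compound 3 `CC(C)CN(CC(C)C)c1ccc(/C(=N/O)Nc2ccc(F)c(Br)c2)cc1NC(=O)Nc1cncnc1` has not been measured. It differs from compound 2 by pyrimidin-5-yl in place of propyl on an amide-type nitrogen. Going by the values given here, the one step measured so far, a 1.2-fold lower number from compound 1 to compound 2 (0.08 log units; within the scatter), concerns the far end of the same chain and changed nothing beyond the scatter; it says nothing about replacing that chain with an aromatic ring carrying two acceptors. Among the compounds with values here, no measured pair in this set bears directly on the change, so no direction can be argued from the data.

Compound 3 is therefore expected to give about 2000 nM in this assay, with a wide range from 400 nM to 10000 nM. The expected step is a 1.3-fold lower number from compound 2 to compound 3 (0.12 log units; within the scatter), centred on no change, with the breadth of the range expressing how little the measured compounds constrain it.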

Compound 3, half-maximal inhibitory concentration: 860 nM
Estimate against measurement, compound 3: 2.3-fold (0.37 log units) above; low and high end bracket the measured number.
By their numbers in this assay, from the lowest: compound 3; then compounds 2 and 1 (each within the scatter of the next).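

Replacing the chain on this amide-type nitrogen with an aromatic ring moves the number in this assay where trimming the chain did not: the read-out shows a 3.0-fold lower number from compound 2 to compound 3 (0.48 log units; beyond the scatter), and the butyl compound gives a 3.6-fold lower number from compound 1 to compound 3 (0.56 log units; beyond the scatter). Both steps are modest, but they show that this position is not indifferent to what it carries, even though no difference could be read between butyl and propyl at the same place. Nothing available explains why pyrimidin-5-yl gives the lower number here.

The compounds shown leave open whether the lower number belongs to an aromatic ring as such or to the hetero atoms of pyrimidin-5-yl, a question that phenyl or pyridin-3-yl on the same amide-type nitrogen would help to settle. They also leave open whether the same change would give a similar step with another group elsewhere on the shared core, for example chlorine in place of the bromine.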